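A few compounds are considered here, and "the series" means these few. Any claim that something is new, unique, unknown or untested is made for them only; others in the source may bear on it.

In a physicochemical assay for solubility, read by HPLC, in phosphate buffer, measured as kinetic solubility, with a stated time of 1 h, at pH 7.4, tested at 250 uM (a lower number here means a less soluble compound, a higher number a more soluble compound), compound 1 `COc1cc(-c2cn(C(=O)NCCCCc3ccccc3)c(=O)o2)ccc1F`, which carries 4-fluoro-3-methoxyphenyl on the shared core, gives < 1000 nM, a limit of the assay. Compound 2 `O=C(NCCCCc1ccccc1)n1cc(-c2cccnc2)oc1=O`, with pyridin-3-yl, gives < 1000 nM, also a limit. Compound 3 `O=C(NCCCCc1ccccc1)n1cc(-c2ccncc2)oc1=O`, with pyridin-4-yl, gives < 1000 nM, again a limit and not a number. Compound 3 therefore has no readable place in the series, and the data so far come down to the limit of < 1000 nM in this assay, at which 3 of the 3 values shown sit.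

Compound 4 `O=C(NCCCCc1ccccc1)n1cc(-c2cnccn2)oc1=O` changes compound 3 in one place: pyrazin-2-yl in place of pyridin-4-yl on an aromatic carbon. In short, it has pyrazin-2-yl in place of pyridin-4-yl on an aromatic carbon.

Among the compounds with values here, three measured steps bear on this exchange, all at the same aromatic carbon. They are a step that the two limits leave unreadable from compound 1 to compound 2, a step that the two limits leave unreadable from compound 1 to compound 3 and a step that the two limits leave unreadable from compound 2 to compound 3. None of them gives a size, so no direction can be carried over, and no shift beyond the scatter is expected in this assay.

The expected step is a step that the limit leaves unreadable from compound 3 to compound 4. For compound 4 the estimated value is 700 nM, with an expected range from 250 nM to 2000 nM, and a report of only a limit is expected to be the likelier outcome.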

Compound 4, solubility: < 1000 nM
Compound 4: no number, only a limit; the forecaster's own chance of this, stated with the estimate: 75%; the middle value does not contradict the limit.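

In this assay compound 4 gives < 1000 nM, again a limit and not a number. Within the data shown here, no step between compound 4 and compound 1, compound 2 or compound 3 can be read. The compounds shown leave open how far the groups on the shared core differ in solubility, as the data come down to one limit: the limit of < 1000 nM in this assay, at which 4 of the 4 values shown sit.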